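Cytotoxicity notes: methyl to ethyl on the shared core

The compounds below may be only part of what the source reports. "The series", "measured", "known", "first", "only" and "open" are said of these compounds alone.

Measured in an ADME assay on BJ cells (Homo sapiens) for cytotoxicity, read by fluorescence, with a stated time of 24 h; on this read-out higher numbers stand for weaker inhibition and lower numbers for stronger inhibition:
compound 1, `CC1S/C(=N\N=C\c2c(-c3ccc(Br)cc3)[nH]c3ccccc23)NC1=O`: > 50000 nM.
compound 2, `O=C1CS/C(=N/N=C/c2c(-c3ccc(Cl)cc3)[nH]c3ccccc23)N1Cc1ccco1`: 8070 nM.
compound 3, `C=CCN1C(=O)C(CC(=O)c2ccc(F)cc2)S/C1=N\N=C\c1ccccc1`: 21500 nM.

The figure of compound 1 is only a limit of this assay, not a number, as noted in the limit of > 50000 nM in this assay, at which 1 of the 3 values shown sits. Compound 2 and compound 3 give numbers, with compound 2 the lower of the two. For the measured compounds named here, no pair of these three differs in a single place, so no measured step is available.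

Compound 4, `CCC1S/C(=N\N=C\c2c(-c3ccc(Br)cc3)[nH]c3ccccc23)NC1=O`, is the next candidate. It differs from compound 1 by methyl in place of hydrogen on a saturated chain carbon bound to a saturated ring carbon. Such a change, read one bond further out, is methyl to ethyl. With compound 1 at a limit, the step is expected to be none beyond the scatter, a step that the limit leaves unreadable from compound 1 to compound 4. Compound 4 is therefore estimated at 60000 nM, between 20000 nM and 200000 nM, most likely again reported only as a limit.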

Compound 4, half-maximal inhibitory concentration: 7450 nM
Compound 4: middle estimate off by 8.1-fold (0.91 log units), on the high side, and the stated range ends above it.
By their numbers in this assay, from the lowest: compounds 4 and 2 (each within the scatter of the next); then compound 3. At a limit, above all of these: compound 1.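

At this position, on a saturated chain carbon bound to a saturated ring carbon, the change from methyl to ethyl is not silent in this assay: it gives an at least 6.7-fold lower number from compound 1 to compound 4 (0.82 log units; beyond the scatter). Compound 1 stands at a limit, > 50000 nM, not at a number. The size of the step therefore remains a bound and not a measure: the limit of > 50000 nM in this assay, at which 1 of the 4 values shown sits.

On these data alone, whether a longer chain, such as propyl, or an amine at this position would move the number further remains open. As far as these compounds go, with a single pair, it is also open whether the same change gives a similar step on other members.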